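The source may report more compounds than this note shows. Statements on the series, on what has been measured and on what is new or still open speak of the compounds shown alone.

Three compounds in this set share one core and differ only in the group attached to the outer aromatic ring. Compound 1 `c1coc(-c2ccnc(Nc3ccc(-n4ccnc4)cc3)n2)c1` gives 2200 nM in a functional assay for inhibition, with Homo sapiens as the target (a lower number here means a stronger inhibitor, a higher number a weaker inhibitor), compound 2 `Cc1cccc(Nc2nccc(-c3ccco3)n2)c1` gives 2100 nM, and compound 3 `CC1CCN(c2cccc(Nc3nccc(-c4ccco4)n3)c2)CC1` gives 5000 nM, the highest of the three numbers. For the measured compounds named here, the step of a 2.4-fold higher number from compound 2 to compound 3 (0.38 log units; beyond the scatter) is the only measured change at this position, and it shows that the 4-methylpiperidin-1-yl group weakens inhibition relative to methyl. Compound 4 `c1ccc(Nc2nccc(-c3ccco3)n2)cc1` removes that group entirely: hydrogen in place of 4-methylpiperidin-1-yl on an aromatic carbon. Because compound 2 gives 2100 nM with the smaller methyl at the same place, compound 4 is expected to return toward that level, a step of a 2.0-fold lower number from compound 3 to compound 4 (0.30 log units; within the scatter). The estimate for compound 4 is 2500 nM, within 1200 nM to 5000 nM.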

Compound 4, half-maximal inhibitory concentration: 32000 nM
Beside the measured number, compound 4's estimate is 13-fold (1.11 log units) below it; measured number outside the range, above it.
By their numbers in this assay, from the lowest: compounds 2 and 1 (each within the scatter of the next); then compound 3; then compound 4.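

With only hydrogen on this aromatic carbon, inhibition falls away: the change gives a 6.4-fold higher number from compound 3 to compound 4 (0.81 log units; beyond the scatter) against 4-methylpiperidin-1-yl, a 15-fold higher number from compound 2 to compound 4 (1.18 log units; beyond the scatter) against methyl and a 15-fold higher number from compound 1 to compound 4 (1.16 log units; beyond the scatter) against 1H-imidazol-1-yl. So a group here, even 4-methylpiperidin-1-yl, gives stronger inhibition than none, which the earlier compounds could not show. Nothing available explains this loss. On these data alone, whether an amine or a carboxylic acid on this carbon would match methyl, and how a longer chain would compare with 4-methylpiperidin-1-yl, remains open.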